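The source may report more compounds than this note shows. Statements on the series, on what has been measured and on what is new or still open speak of the compounds shown alone.

In a functional assay on the whole organism for positive allosteric modulation, with Rattus norvegicus as the target (a higher number here means that more compound is needed for the effect, a lower number that less compound is needed), compound 1, whose structure is `Cc1nn(C)c2c1C(c1ccccc1)=NCCN2`, gives 2.5 mg/kg. Compound 2, with the structure `Cc1nn(C)c2c1C(c1ccccc1)=NCCN2CCCN(C)C`, differs from compound 1 only in the change (3-(dimethylamino)propyl in place of hydrogen on a nitrogen on an aromatic ring in a ring). For compound 2 the result in this assay is a limit rather than a number, > 10 mg/kg. The step is therefore an at least 4.0-fold higher number from compound 1 to compound 2 (0.60 log units; beyond the scatter), and the size of this step is known only as a floor, because of the limit of > 10 mg/kg in this assay, at which 1 of the 3 values shown sits.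

Compound 3 has the structure `CCc1nn(C)c2c1C(c1cccc(F)c1)=NCCN2`, and in this assay compound 3 gives 2.5 mg/kg, which lies level with compound 1 at the digits shown. The difference between the core of compound 3 and the core of compound 1 is not broken down here.

Compound 4, structure `CCc1nn(C)c2c1C(c1cccc(F)c1)=NCCN2CCCN(C)C`, is not yet measured. It stands to compound 3 as compound 2 stands to compound 1: the change (3-(dimethylamino)propyl in place of hydrogen on a nitrogen on an aromatic ring in a ring). The surroundings are not identical, since in compound 3 the ring atom bears a 3-fluorophenyl group where in compound 1 it bears a phenyl group, so this is the same kind of change rather than the same change.

Since the same kind of change produced an at least 4.0-fold higher number from compound 1 to compound 2 (0.60 log units; beyond the scatter), a step of a 6.0-fold higher number from compound 3 to compound 4 (0.78 log units; beyond the scatter) is expected here too. Compound 4 is accordingly estimated to give 15 mg/kg in this assay, with a plausible span from 5 mg/kg to 40 mg/kg, and the result may again come back only as a limit.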

Compound 4, minimum effective dose: > 10 mg/kg
Compound 4: no number, only a limit (the forecaster's own chance of this, stated with the estimate: 70%); the middle value is on the limit's open side.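

In this assay, 3-(dimethylamino)propyl in place of hydrogen on a nitrogen on an aromatic ring in a ring gives an at least 4.0-fold higher number from compound 3 to compound 4 (0.60 log units; beyond the scatter), so on the core of compound 3, as on the core of compound 1, more compound is needed once this chain is present. For compound 4 the result, > 10 mg/kg, is a limit of the assay and not a number. The direction of the change therefore carries over between these two cores, which share this chain and differ elsewhere, but the data cannot say whether the step is equally large on both: the same change on two cores in this assay, an at least 4.0-fold higher number (0.60 log units; beyond the scatter) from compound 1 to compound 2 and an at least 4.0-fold higher number (0.60 log units; beyond the scatter) from compound 3 to compound 4; the limit leaves it open whether they differ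

The compounds shown have only hydrogen or 3-(dimethylamino)propyl at this place, so it remains open how a methyl group, a shorter chain, a longer chain or a chain ending in a carboxylic acid would behave there. Going by these compounds, it also remains open whether only the amine at the end of the chain or the chain as a whole goes with the higher number, and whether the same direction would hold on cores beyond these two.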